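A Cyclohexyl Replaces the Iodophenyl on the Shared Core

The source may hold more compounds than are shown below. What is called first, only, known or untested is meant among the compounds shown, and "the series" means these compounds.

Compound 3 `Ic1ccc(Cn2ccc3nc(-c4ccccc4)nc-3c2)cc1` is the only one of the three measured compounds that returns a number in an ADME assay on MDBK cells (Bos taurus) for cytotoxicity; a higher number here means that more compound is tolerated, a lower number that less compound is tolerated; compound 3 gives 22000 nM. Compound 1 `Clc1ccc(Cn2ccc3nc(-c4ccccc4)nc-3c2)cc1` reaches only the limit of the assay, at > 100000 nM. Compound 2 `Brc1ccccc1Cn1ccc2nc(-c3ccccc3)nc-2c1` likewise sits at the limit, at > 100000 nM. Compound 4 `c1ccc(-c2nc3ccn(CC4CCCCC4)cc-3n2)cc1` differs from compound 3 by cyclohexyl in place of 4-iodophenyl on a saturated chain carbon bound to an aromatic nitrogen. Going by the values given here, the steps that bear on this change are an at least 4.5-fold lower number from compound 1 to compound 3 (0.65 log units; beyond the scatter) and an at least 4.5-fold lower number from compound 2 to compound 3 (0.65 log units; beyond the scatter), both ending at the one read number. Removing the 4-iodophenyl is therefore expected to move the number back up in this assay, by a 2.7-fold higher number from compound 3 to compound 4 (0.44 log units; beyond the scatter), perhaps to the limit again. Compound 4 is estimated at 60000 nM, within 20000 nM to 150000 nM.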

Compound 4, half-maximal cytotoxic concentration: > 100000 nM
Compound 4: no number, only a limit; the forecaster's own chance of this, stated with the estimate: 50%; middle value at least 1.6-fold (0.22 log units) away from the limit.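

Cyclohexyl in place of 4-iodophenyl gives an at least 4.5-fold higher number from compound 3 to compound 4 (0.65 log units; beyond the scatter) in this assay. This shows that a non-aromatic ring of carbon only, carrying no halogen, also sits at this place without a read number appearing, leaving compound 3 as the one exception among the compounds shown. The value of compound 4 is a limit and not a number, and the steps between it and compound 1 or compound 2 cannot be read: the limit of > 100000 nM in this assay, at which 3 of the 4 values shown sit.

As far as these compounds go, how far these limit compounds differ remains open. So does whether an amine or a carboxylic acid on the cyclohexyl, or a longer chain before it, would bring a read number.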